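This account rests on a few compounds, and the source may have more. Where it says the series, first, only, none or still open, it means among the compounds named here.

Measured compounds:
Compound 1 `COc1ccccc1N1CCN(CCCNS(=O)(=O)c2ccc3ncccc3c2)CC1`: 825 nM
Compound 2 `COc1ccccc1N1CCN(CCCCNS(=O)(=O)c2cccc3cccnc23)CC1`: "not determined" (no result reported)
Compound 3 `O=S(=O)(NCCCCN1CCC2CCCCC2C1)c1cnc2ccccc2c1`: "not determined" (no result reported)

Among the compounds with values here, in an assay on HEK293 cells for displacement of a labelled ligand from 5-hydroxytryptamine receptor 6 (Homo sapiens), read by scintillation counting, with a stated time of 1 h (a lower number here means a stronger inhibitor, a higher number a weaker inhibitor), compound 1 gives 825 nM, and this is the only number in the set, since compound 2 and compound 3 carry no reported result. Within the data shown here, compound 1 therefore stands alone, and no step between measured compounds can be read from these data. Compound 4 `CCN(CCCN1CCN(c2ccccc2OC)CC1)S(=O)(=O)c1ccc2ncccc2c1` differs from compound 1 by ethyl in place of hydrogen on a sulfonamide nitrogen. Among the measured compounds shown here, with no measured step to lean on, the expectation for this change in this assay is a small shift, probably towards a weaker inhibitor, and one that may not exceed the usual scatter. For compound 4 the expected value in this assay is 1200 nM, with a range from 400 nM to 4000 nM, so that the estimated step from compound 1 to compound 4 is a 1.5-fold higher number from compound 1 to compound 4 (0.16 log units; within the scatter).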

Compound 4, inhibition constant: 1920 nM
For compound 4 the middle estimate is 1.6-fold (0.20 log units) below the measured one; the measured number falls inside the stated range.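

In this assay, within the data shown here, ethyl in place of hydrogen on a sulfonamide nitrogen gives a 2.3-fold higher number from compound 1 to compound 4 (0.37 log units; beyond the scatter) and this is the first step that can be read in the set. It shows that the change at this position weakens the compound modestly, by more than the usual scatter, while compound 4 still gives a measurable inhibition constant. Nothing given here explains the shift.

The compounds shown leave open whether methyl, a longer chain or an amine-bearing chain on this nitrogen would give a smaller or larger step. They also leave open whether ethyl has the same effect on other cores.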